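The source may report more compounds than this note shows. Statements on the series, on what has been measured and on what is new or still open speak of the compounds shown alone.

Measured in a functional assay on A549 cells (Homo sapiens) for inhibition, read by MTT assay, with a stated time of 72 h; on this read-out lower numbers stand for stronger inhibition and higher numbers for weaker inhibition:
- compound 1 `Nc1ncnc2c1c(-c1cnc3[nH]ccc3c1)nn2CC(=O)NO`: > 150000 nM, a limit
- compound 2 `Nc1nc2cc(-c3nn(CCCCCCCCCC(=O)NO)c4ncnc(N)c34)ccc2o1`: > 50000 nM, a limit

Not yet measured: compound 3 `CNC(=O)CCCCCCCn1nc(-c2ccc3oc(N)nc3c2)c2c(N)ncnc21`.

Compound 2 has no number in this assay, only the limit > 50000 nM. Compound 1 likewise has only a limit, > 150000 nM. Within the data shown here, no order can be read from these two entries, and no measured step gauges the change that comes next.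

Compound 3 differs from compound 2 as follows: methylcarbamoyl in place of 2-(hydroxycarbamoyl)ethyl on a saturated chain carbon, seven bonds along the chain from an aromatic nitrogen. In words, this is methylcarbamoyl in place of 2-(hydroxycarbamoyl)ethyl on a saturated chain carbon, seven bonds along the chain from an aromatic nitrogen. The same difference also reads 5-(hydroxycarbamoyl)pentyl to 3-(methylcarbamoyl)propyl.

The expectation starts from compound 2 at > 50000 nM, which is a limit, and no gain in inhibition is expected from this starting point. The expected size of a step that the limit leaves unreadable from compound 2 to compound 3 is none beyond the scatter. For compound 3 the estimated value is 70000 nM, with an expected range of 25000 nM to 200000 nM. A report as a limit alone is also expected to be likely.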

Compound 3, half-maximal inhibitory concentration: 8360 nM
Estimate against measurement, compound 3: 8.4-fold (0.92 log units) above; measured number below the stated range.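

In this assay compound 3, with methylcarbamoyl in place of 2-(hydroxycarbamoyl)ethyl on a saturated chain carbon, seven bonds along the chain from an aromatic nitrogen, gives 8360 nM, the only actual number among the compounds shown. The change brings an at least 5.9-fold lower number from compound 2 to compound 3 (0.77 log units; beyond the scatter), so at this position a measurable value does not depend on the hydroxycarbamoyl end group, which neither earlier compound could show. The true size of this step stays unknown because compound 2 has no number, only a limit: the limit of > 50000 nM in this assay, at which 1 of the 3 values shown sits.

The change shortens the chain and replaces the end group in one move, so the two effects cannot be separated here, and steps involving compound 1 cannot be read. Open, from the compounds shown here alone, are a methylcarbamoyl group on the longer chain of compound 2, a hydroxycarbamoyl group on the shorter chain of compound 3, and a carboxylic acid or a primary amide at the end of either chain, any of which would show whether the end group, the chain length or both carry the step.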